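The source may hold more compounds than are shown below. What is called first, only, known or untested is meant among the compounds shown, and "the series" means these compounds.

Working notes on the series. Compound 1 `O=C1OCCc2c(CO)cccc21` carries the shared core with a free hydroxyl on a saturated carbon. In an ADME assay on HepG2 2.2.15 cells (Homo sapiens) for cytotoxicity, read by MTT assay, with a stated time of 72 h (a higher number here means that more compound is tolerated, a lower number that less compound is tolerated), compound 1 gives > 3800000 nM, which is a limit of the assay and not a number. Compound 2 `CC(=O)OCc1cccc2c1CCOC2=O` has acetyl in place of hydrogen on an oxygen on a saturated carbon. In this assay compound 2 gives > 2430000 nM, again a limit. Compound 3 `CCCCCCCC(=O)OCc1cccc2c1CCOC2=O` has hexyl in place of hydrogen on a saturated chain carbon bound to a carbonyl carbon. In this assay compound 3 gives > 3450000 nM, also a limit. Accordingly the step that the two limits leave unreadable from compound 1 to compound 2 and the step that the two limits leave unreadable from compound 2 to compound 3 cannot be sized, since every value sits at a limit of > 2430000 nM in this assay, at which 1 of the 3 values shown sits, the limit of > 3450000 nM in this assay, at which 1 of the 3 values shown sits (the limit of > 3800000 nM in this assay, at which 1 of the 3 values shown sits). Compound 3 therefore stands only at a limit, as do the two other values shown.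

Compound 4 `O=C1OCCc2c(COC(=O)C3CCCCC3)cccc21` differs from compound 3 by cyclohexyl in place of heptyl on a carbonyl carbon. The two measured steps bear on this change only as unreadable ones, so no size or direction can be drawn from them. Compound 4 is expected to give a limit again in this assay. The estimate for compound 4 is 3500000 nM, with a range from 1500000 nM to 10000000 nM. The expected step that the limit leaves unreadable from compound 3 to compound 4 is estimated to be none beyond the scatter.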

Compound 4, half-maximal cytotoxic concentration: > 1840000 nM
Compound 4: only a limit was reported (the forecaster's own chance of this, stated with the estimate: 90%); the middle value lies beyond the limit too.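

In this assay compound 4 gives > 1840000 nM, which is a limit of the assay. The steps from compound 2 and compound 3 to compound 4 cannot be read. The compounds shown leave open whether the group on the carbonyl carbon alters tolerated concentration at all.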